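Swapping methylamino for ethoxy on a carbonyl carbon

The source may report more compounds than this note shows. Statements on the series, on what has been measured and on what is new or still open speak of the compounds shown alone.

Compound 1 `CNC(=O)/C=C/c1ccncc1-c1ccc2ccccc2c1`: 8680 nM
Compound 2 `CNC(=O)/C=C/c1ccncc1-c1ccc2cc[nH]c2c1`: 7680 nM

Both values come from a functional assay on MDA-MB-231 cells (Homo sapiens) for inhibition, read by sulforhodamine B assay, with a stated time of 72 h; on this read-out lower numbers stand for stronger inhibition of growth and higher numbers for weaker inhibition of growth. Compound 1 and compound 2 lie within the usual scatter of each other, so neither can be ranked above the other. Compound 3 `CCOC(=O)/C=C/c1ccncc1-c1ccc2ccccc2c1` keeps the core of compound 1 but carries ethoxy in place of methylamino on a carbonyl carbon. Among the compounds with values here, no measured pair shows this change, so the expectation is loose: no step beyond the scatter in this assay, with a slight lean toward stronger inhibition of growth. The estimated change is a 1.4-fold lower number from compound 1 to compound 3 (0.16 log units; within the scatter). For compound 3 the expected value is 6000 nM, within an estimated range from 2000 nM to 18000 nM.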

Compound 3, concentration for 50% growth inhibition: 8090 nM
The estimate for compound 3 lay 1.3-fold (0.13 log units) below the measured number, and the stated range covers the measured number.
By their numbers in this assay, from the lowest: compounds 2, 3 and 1 (each within the scatter of the next).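

Putting ethoxy in place of methylamino on a carbonyl carbon gives a 1.1-fold lower number from compound 1 to compound 3 (0.03 log units; within the scatter). This swap removes the hydrogen-bond donor of methylamino and adds an ester oxygen, yet the two compounds still cannot be told apart, so in this pair growth inhibition does not depend on that donor. No measurement at hand offers an explanation for this result.

As far as these compounds go, whether a carboxylic acid or a longer chain such as butoxy on this carbonyl carbon would also stay within the scatter remains open. So does whether the same swap on compound 2 would give the same outcome.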